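Swapping cyano for methyl at the short-lived end

This account rests on a few compounds, and the source may have more. Where it says the series, first, only, none or still open, it means among the compounds named here.

Three compounds on a shared core have numbers in an ADME assay on microsomes from liver (Homo sapiens) for metabolic stability; on this read-out lower numbers stand for a shorter-lived compound and higher numbers for a longer-lived compound. Compound 1 (`CC#C[C@@H](Cc1nnn[nH]1)c1ccc(OCc2ccc3sc(F)c(-c4ccc(OCCOC)cc4C)c3c2)cc1`) gives 1.95 h, compound 3 (`CC#C[C@@H](Cc1nnn[nH]1)c1ccc(OCc2ccc3scc(-c4cncnc4C)c3c2)cc1`) gives 0.233 h, and compound 2 (`CC#C[C@@H](Cc1nnn[nH]1)c1ccc(OCc2ccc3sc(C#N)c(-c4ccccc4C)c3c2)cc1`) gives 0.0333 h. Compound 2 is the lowest of the three, and its gaps to compound 3 and to compound 1 both lie beyond the scatter.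

Compound 4 (`CC#C[C@@H](Cc1nnn[nH]1)c1ccc(OCc2ccc3sc(C)c(-c4ccccc4C)c3c2)cc1`) differs from compound 2 in one place: methyl in place of cyano on an aromatic carbon. For the measured compounds named here, no measured pair shows this change on its own, and compound 1 and compound 3 also differ from compound 2 elsewhere, so they give only a loose guide. With compound 2 at the bottom of the measured range at 0.0333 h, a rise is expected to be more likely than a fall. The expected move is a 3.0-fold higher number from compound 2 to compound 4 (0.48 log units; beyond the scatter), upward and moderately beyond the scatter. For compound 4 the estimate is 0.1 h, with an expected range of 0.03 h to 0.4 h.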

Compound 4, half-life: 0.0667 h
Compound 4: middle estimate off by 1.5-fold (0.18 log units), on the high side, within the range that was stated.
By their numbers in this assay, from the lowest: compounds 2 and 4 (each within the scatter of the next); then compound 3; then compound 1.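

Exchanging cyano for methyl on the aromatic carbon next to the ring sulfur, with the 2-methylphenyl group held constant, gives a 2.0-fold higher number from compound 2 to compound 4 (0.30 log units; within the scatter) in this assay, so this pair does not separate the two groups. The short half-life of compound 2 is therefore not specific to cyano in this one comparison, although a single pair cannot show a general pattern at this position. No measurement at hand gives a reason for this result.

Open, on these data alone, is whether a different group at this position, such as an amine or a carboxylic acid, would move the half-life beyond the scatter with the rest of compound 4 unchanged. Also open is which structural differences account for the numbers of compound 1 and compound 3, since each differs from compound 2 and compound 4 in more than one place.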